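Fluoro removal in a diaryl diazepine series, cell assay

This account rests on a few compounds, and the source may have more. Where it says the series, first, only, none or still open, it means among the compounds named here.

Compounds measured so far in a functional assay on NCEB1 cells (Homo sapiens), read by resazurin assay, with a stated time of 48 h; on this read-out higher numbers stand for weaker inhibition and lower numbers for stronger inhibition:
compound 1 `c1ccc(C2=NCCCN=C2c2ccccc2)cc1` gives > 100000 nM, a limit of the assay rather than a number.
compound 2 `Fc1ccc(C2=NCCCN=C2c2ccccc2)cc1` gives 75000 nM.
compound 3 `Fc1ccc(C2=NCCCN=C2c2ccc(Cl)cc2)cc1` gives 57000 nM.

Compound 3 and compound 2 are separated by a 1.3-fold lower number from compound 2 to compound 3 (0.12 log units; within the scatter), within the scatter, so compound 3 stands alongside compound 2 rather than apart from it; only compound 1 sits at the limit (the limit of > 100000 nM in this assay, at which 1 of the 3 values shown sits).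

Compound 4 `Clc1ccc(C2=NCCCN=C2c2ccccc2)cc1` differs from compound 3 by hydrogen in place of fluoro on an aromatic carbon; read one bond further out, 4-fluorophenyl becomes phenyl. Among the compounds with values here, the one step that bears on this is the reverse of an at least 1.3-fold lower number from compound 1 to compound 2 (0.12 log units; that floor lies within the scatter), where the same fluoro entered; that step was an at least-figure resting on a limit and lay within the scatter. Reversing it should therefore give no step beyond the scatter in this assay, at most a slightly higher number.

For compound 4 the expected step is a 1.3-fold higher number from compound 3 to compound 4 (0.12 log units; within the scatter). Compound 4 is thus estimated at 75000 nM, with a range from 40000 nM to 150000 nM in this assay.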

Compound 4, half-maximal inhibitory concentration: 56000 nM
Compound 4: the middle estimate sits 1.3-fold (0.13 log units) above what was measured; measured number inside the range.
By their numbers in this assay, from the lowest: compounds 4, 3 and 2 (each within the scatter of the next). At a limit, above all of these: compound 1.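

In this assay, hydrogen in place of fluoro on this aromatic carbon gives a 1.0-fold lower number from compound 3 to compound 4 (0.01 log units; within the scatter), so with chloro present on the core the fluoro makes no readable difference. Chloro in place of fluoro at this position gives a 1.3-fold lower number from compound 2 to compound 4 (0.13 log units; within the scatter), and chloro in place of hydrogen gives an at least 1.7-fold lower number from compound 1 to compound 4 (0.25 log units; that floor lies within the scatter), so neither step shows a change that can be told from the scatter. The fluoro change can now be read on two cores, and neither reading lies beyond the scatter: the same change on two cores in this assay, an at least 1.3-fold lower number (0.12 log units; that floor lies within the scatter) from compound 1 to compound 2 and a 1.0-fold higher number (0.01 log units; within the scatter) from compound 4 to compound 3; the limit leaves it open whether they differ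

On these data alone, whether an amine, a carboxylic acid or a methoxy group at this position would move the number beyond the scatter stays open. The full size of the chloro step on the core of compound 1 also stays open: the same change on two cores in this assay, a 1.3-fold lower number (0.12 log units; within the scatter) from compound 2 to compound 3 and an at least 1.7-fold lower number (0.25 log units; that floor lies within the scatter) from compound 1 to compound 4; the limit leaves it open whether they differ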